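Bromo removal in a polyfluorinated arylsulfonamide series

The compounds below may be only part of what the source reports. "The series", "measured", "known", "first", "only" and "open" are said of these compounds alone.

Measured compounds:
compound 1, `COc1ccc(NS(=O)(=O)c2c(F)c(F)c(F)c(F)c2Br)cc1`, 160 nM
compound 2, `COc1ccc(NS(=O)(=O)c2cc(F)c(F)c(F)c2F)cc1`, 370 nM
compound 3, `COc1ccc(NS(=O)(=O)c2c(F)c(F)c(Br)c(F)c2F)cc1`, 17000 nM

In a functional assay on HeLa cells (Homo sapiens) for cytotoxicity (a higher number here means a weaker inhibitor of growth, a lower number a stronger inhibitor of growth), compound 1 gives 160 nM. Compound 2 is the same molecule with the bromo taken off the sulfonyl-bearing ring; the change is hydrogen in place of bromo on an aromatic carbon, and it produced a 2.3-fold higher number from compound 1 to compound 2 (0.36 log units; beyond the scatter).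

Compound 3 carries the same atoms as compound 1 joined differently; how the two cores differ is not broken down here. Its value in this assay stands far apart from both: compound 3 gives 17000 nM, a much higher number than compound 2 or compound 1.

Compound 4, `COc1ccc(NS(=O)(=O)c2c(F)c(F)cc(F)c2F)cc1`, is not yet measured. It differs from compound 3 by hydrogen in place of bromo on an aromatic carbon. This is the same kind of change as that from compound 1 to compound 2, but not the same: in compound 1 the bromo sits ortho to a fluoro group and ortho to a large group and para to a fluoro group, whereas in compound 3 it sits ortho to two fluoro groups and para to a large group.

Compound 4 ends as a tetrafluoro ring like compound 2, which gives 370 nM, so the expected step of a 14-fold lower number from compound 3 to compound 4 (1.15 log units; beyond the scatter) is a drop, against the modest rise from compound 1 to compound 2. Among the measured compounds shown here, because the only measured step of this kind, a 2.3-fold higher number from compound 1 to compound 2 (0.36 log units; beyond the scatter), went the other way, the estimate is wide. For compound 4 the expected value in this assay is 1200 nM, with a range from 250 nM to 6000 nM.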

Compound 4, concentration for 50% growth inhibition: > 50000 nM
Compound 4: no number, only a limit; the forecaster's own chance of this, stated with the estimate: 5%; middle value at least 41-fold (1.61 log units) from the limit.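

Compound 4 reads > 50000 nM in this assay, and this is a limit of the assay, not a number. Hydrogen in place of bromo gives an at least 2.9-fold higher number from compound 3 to compound 4 (0.46 log units; beyond the scatter), which has the same direction as a 2.3-fold higher number from compound 1 to compound 2 (0.36 log units; beyond the scatter), so on these two cores, the only ones available for this comparison, removing the bromo gives a weaker inhibitor of growth each time. This shows that the direction of the change held on both cores, but it does not show that the size carried over, and no true size can be given for the step on the core of compound 3: the same change on two cores in this assay, a 2.3-fold higher number (0.36 log units; beyond the scatter) from compound 1 to compound 2 and an at least 2.9-fold higher number (0.46 log units; beyond the scatter) from compound 3 to compound 4; the limit leaves it open whether they differ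

Still open, on these data alone, is how the number would respond if an amine or a nitrile, rather than bromo or hydrogen, stood on the aromatic carbon para to a large group, and whether either group would restore growth inhibition on the core of compound 4. Also open, as far as these compounds go, is whether the same order of results would hold if a carboxylic acid or a longer chain replaced the methoxy group on the other ring.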